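A few compounds are considered here, and "the series" means these few. Any claim that something is new, unique, unknown or untested is made for them only; others in the source may bear on it.

The measured compounds:

compound 1 `O=C(Nc1nc2ccc(F)cc2s1)c1cc(-c2ccc(F)cc2)n2nc(-c3ccccc3)cc2n1` — 35500 nM
compound 2 `COc1cc(-c2cc(C(=O)Nc3nc4ccc(F)cc4s3)nc3cc(-c4ccccc4)nn23)cc(OC)c1OC` — 32400 nM

Among the measured compounds shown here, in a functional assay on ACHN cells (Homo sapiens) for cytotoxicity, read by MTT assay, with a stated time of 48 h (a lower number here means a stronger inhibitor, a higher number a weaker inhibitor), compound 2 gives 32400 nM, the lowest of the two numbers so far, while compound 1 gives 35500 nM. For the measured compounds named here, the single measured step, a 1.1-fold lower number from compound 1 to compound 2 (0.04 log units; within the scatter), lies within the scatter, so the two compounds cannot be set apart by potency.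

Compound 3 `COc1cc(-c2cc(C(=O)Nc3nc4cc(C)c(C)cc4s3)nc3cc(-c4ccccc4)nn23)cc(OC)c1OC` differs from compound 2 by 5,6-dimethyl-1,3-benzothiazol-2-yl in place of 6-fluoro-1,3-benzothiazol-2-yl on an amide-type nitrogen. Going by the values given here, this change sits at the opposite end of the molecule from the one measured step, which touches the aryl group on the shared core rather than the amide side. Among the compounds with values here, no measured step therefore bears directly on it; the only guide is that the one change tried so far, a 1.1-fold lower number from compound 1 to compound 2 (0.04 log units; within the scatter), left the number where it was. With nothing pointing either way, the expected step from compound 2 to compound 3 in this assay is a 1.1-fold lower number from compound 2 to compound 3 (0.03 log units; within the scatter), a change not expected to go beyond the scatter. Compound 3 is accordingly estimated at 30000 nM, with a range from 8000 nM to 100000 nM.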

Compound 3, half-maximal inhibitory concentration: 3800 nM
Estimate against measurement, compound 3: 7.9-fold (0.90 log units) above; the whole stated range lies above it.
By their numbers in this assay, from the lowest: compound 3; then compounds 2 and 1 (each within the scatter of the next).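

In this assay, the group on the amide-type nitrogen proves to be a place where a single change moves the number clearly: 5,6-dimethyl-1,3-benzothiazol-2-yl in place of 6-fluoro-1,3-benzothiazol-2-yl gives an 8.5-fold lower number from compound 2 to compound 3 (0.93 log units; beyond the scatter). The earlier change at the aryl group on the shared core gave only a 1.1-fold lower number from compound 1 to compound 2 (0.04 log units; within the scatter), so among these three compounds, only the step on the amide side goes beyond the scatter. Nothing available here explains why this replacement changes the number.

The replacement removes a fluorine and adds two methyl groups in one step, so these compounds cannot show whether the difference follows the loss of the fluorine, the gain of the methyl groups, or both together. Still open, on these data alone, is how a 1,3-benzothiazol-2-yl group with a single methyl, a chloro or an ethyl group would compare, and whether the 5,6-dimethyl-1,3-benzothiazol-2-yl group would give a similar step if 4-fluorophenyl replaced 3,4,5-trimethoxyphenyl on the core.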